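The compounds below may be only part of what the source reports. "The series", "measured", "known", "first", "only" and "open" are said of these compounds alone.

Compound 1, `Cc1ccc(S(=O)(=O)NCc2cn(C[C@H](O)[C@H]3OC(=O)C(OCc4ccccc4)=C3OCc3ccccc3)nn2)cc1`, is one of three compounds whose antiproliferative activity has been measured in a functional assay on SW-620 cells (Homo sapiens) for antiproliferative activity, read by MTT assay, with a stated time of 72 h; a higher number here means a weaker inhibitor, a lower number a stronger inhibitor. In this assay compound 1 gives 45800 nM, the lowest of the two numbers recorded, with compound 2, `O=C1O[C@H]([C@@H](O)Cn2cc(-c3cc(C(F)(F)F)cc(C(F)(F)F)c3)nn2)C(OCc2ccccc2)=C1OCc1ccccc1`, close by at 49200 nM, a gap that lies within the scatter. Compound 3, `O=C1O/C(=C\Cn2cc(-c3cc(C(F)(F)F)cc(C(F)(F)F)c3)nn2)C(OCc2ccccc2)=C1OCc1ccccc1`, yields only a limit of the assay, > 100000 nM, as noted in the limit of > 100000 nM in this assay, at which 1 of the 3 values shown sits, so no number is available for it.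

Compound 4, `CCCCCc1ccc(-c2cn(C[C@H](O)[C@H]3OC(=O)C(OCc4ccccc4)=C3OCc3ccccc3)nn2)cc1`, has not yet been measured. It differs from compound 1 in one place: 4-pentylphenyl in place of (((4-methylphenyl)sulfonyl)amino)methyl on an aromatic carbon. The new group sits on an aromatic carbon of a five-membered aromatic ring with 3 nitrogen, two ring bonds from the ring atom that bears a large group. Compound 2 already carries an aryl group on that ring and gives a value within the scatter of compound 1, so an aryl group at this position by itself does not appear to move the number far.

On this basis compound 4 is expected to show no step beyond the scatter, with a 1.4-fold lower number from compound 1 to compound 4 (0.16 log units; within the scatter) as the estimate of the change from compound 1. The value of compound 4 in this assay is estimated at 32000 nM, within a range from 10000 nM to 90000 nM.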

Compound 4, half-maximal inhibitory concentration: 12200 nM
Compound 4: the middle estimate sits 2.6-fold (0.42 log units) above what was measured; the range from low to high includes it.
By their numbers in this assay, from the lowest: compound 4; then compounds 1 and 2 (each within the scatter of the next). At a limit, above all of these: compound 3.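

In this assay, the exchange of (((4-methylphenyl)sulfonyl)amino)methyl for 4-pentylphenyl gives a 3.8-fold lower number from compound 1 to compound 4 (0.57 log units; beyond the scatter), which shows that a change on this aromatic carbon of the five-membered aromatic ring with 3 nitrogen can move the number beyond the scatter, something the earlier compounds had not shown. An aryl group on this carbon does not settle the number by itself: compound 2, which also carries one there, gives 49200 nM, whereas compound 4 gives 12200 nM. The entering group carries no hydrogen-bond donor or acceptor while the leaving group carries both, but nothing shown ties the step to that difference or to any other cause.

The compounds shown leave open whether the step belongs to the pentyl chain or to the phenyl ring, which a plain phenyl, a methyl or a longer chain such as octyl in its place would begin to separate. They also leave open how the number would respond to an amine or a carboxylic acid at the end of that chain.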